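A few compounds are considered here, and "the series" means these few. Any claim that something is new, unique, unknown or untested is made for them only; others in the source may bear on it.

Measured so far: compound 1 `CN(C)c1ccc2c(=O)c(C(=O)Nc3cc(F)cc(F)c3)cn(-c3ccc(OCCCCCCC[N+]45CCN(CC4)CC5)cc3Cl)c2n1` with 80% in an assay on LX2 cells for inhibition of COL1A1 promoter (Homo sapiens), read by a luciferase reporter, with a stated time of 24 h, tested at 50 uM (on this read-out higher numbers stand for a stronger effect at the one concentration tested and lower numbers for a weaker effect), and compound 2 `CC[N+]1(CCCCCCCOc2ccc(-n3cc(C(=O)Nc4cc(F)cc(F)c4)c(=O)c4ccc(N(C)C)nc43)c(Cl)c2)CCCCC1`, for which compound 2 is recorded as "not active" (no number reported), with no number given.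

Compound 2 therefore stands without a single value; it only shows that the two measured compounds differ in outcome. Compound 3 `CN(C)c1ccc2c(=O)c(C(=O)Nc3cc(F)cc(F)c3)cn(-c3ccc(OCCCCCCC[N+](C)(C)C4CCCCC4)cc3Cl)c2n1` carries the change (a group of 9 heavy atoms (8 carbon, 1 nitrogen; one six-membered non-aromatic ring of carbon only) in place of a group of 8 heavy atoms (7 carbon, 1 nitrogen; one six-membered non-aromatic ring with 1 hetero atom), on a saturated chain carbon, seven bonds along the chain from an oxygen on an aromatic ring). Among the compounds with values here, no step between measured compounds is available to size this change. Compound 1 shows that a quaternary nitrogen on this chain can be active, while compound 2 shows it need not be. For compound 3 an intermediate result is expected, estimated at 35% with a range of 0% to 75%, with a real chance that only a limit is reported.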

Compound 3, a percentage reported as inhibition, at one concentration (the size of the read-out at that concentration, not a potency): "not active" (no number reported)
No number was reported for compound 3, so the estimate cannot be set against anything.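

Compound 2 and compound 3 both lack a number, so no new step can be read between them. The compounds shown leave open how far the chain-end group of compound 1 can be altered with activity retained. No measured evidence bears on this result.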